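The compounds below may be only part of what the source reports. "The series", "measured", "known", "first", "only" and "open" are said of these compounds alone.

Measured so far:
- compound 1, `CC1COC2(C)Oc3c(c4c(c5c3CC3C(C)COC3(C)O5)CC3C(C)COC3(C)O4)CC12`: 11000 nM
- compound 2, `CCCOc1cc2c(c3c1C[C@@H]1[C@@H](C)CO[C@]1(C)O3)C[C@@H]1[C@@H](C)CO[C@]1(C)O2`: 77000 nM

In a functional assay on aorta (Rattus norvegicus, strain Sprague-Dawley) for inhibition (on this read-out lower numbers stand for an effect already at smaller amounts and higher numbers for an effect only at larger amounts of compound), compound 1 gives 11000 nM, and compound 2 gives 77000 nM. Among the compounds with values here, compound 2 therefore stands at the higher of the two numbers; the only other value, that of compound 1, lies well under it, and the gap between the two is beyond the usual scatter. Within the data shown here, the two compounds share no single-point step, so the gap says nothing about any one group.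

Compound 3, `CCCCCCOc1cc2c(c3c1C[C@@H]1[C@@H](C)CO[C@]1(C)O3)C[C@@H]1[C@@H](C)CO[C@]1(C)O2`, has not been measured. It differs from compound 2 in one place: propyl in place of hydrogen on a saturated chain carbon, three bonds along the chain from an oxygen on an aromatic ring. Read one bond further out, this is propyl to hexyl on the chain at the oxygen on the aromatic ring.

Among the measured compounds shown here, no measured pair shows what lengthening this chain does in this assay. The expectation for the step from compound 2 to compound 3 is therefore a small move toward a lower number, a 1.9-fold lower number from compound 2 to compound 3 (0.28 log units; within the scatter), not clearly beyond the scatter. Compound 3 is estimated at 40000 nM, with a range from 12000 nM to 130000 nM.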

Compound 3, half-maximal effective concentration: > 200000 nM
Compound 3: a limit, no number (the forecaster's own chance of this, stated with the estimate: 10%); middle value at least 5.0-fold (0.69 log units) from the limit.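

In this assay, within the data shown here, the change from propyl to hexyl on the chain at the oxygen on the aromatic ring gives the first reading of a single change at this position: an at least 2.5-fold higher number from compound 2 to compound 3 (0.41 log units; beyond the scatter). For compound 3, the reading of > 200000 nM is a limit of the assay and not a number. Lengthening the chain at this position therefore moves the read-out toward effects only at larger amounts of compound, and the size of the move stays unfixed, with the whole reading resting on one pair and on this bound: the limit of > 200000 nM in this assay, at which 1 of the 3 values shown sits.

Butyl and pentyl chains, which lie between propyl and hexyl, are not among the compounds shown, and neither are the shorter methyl and ethyl chains, so it remains open whether the read-out changes steadily with chain length or only beyond a certain length. Also open, from the compounds shown here alone, is whether an amine or a carboxylic acid on this chain would give a different reading from the plain hexyl chain in this assay.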